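This account rests on a few compounds, and the source may have more. Where it says the series, first, only, none or still open, it means among the compounds named here.

Measured compounds:
compound 1 `NNC(=O)CCc1ccncc1-c1ccc2ccccc2c1` with 7.7 nM in an assay on a protein complex for inhibition of CDK8/Cyclin C (Homo sapiens), with a stated time of 1 h; on this read-out higher numbers stand for weaker inhibition and lower numbers for stronger inhibition;
compound 3 `CCOC(=O)/C=C/c1ccncc1-c1ccc2ccccc2c1` with 53.3 nM in this assay;
compound 2 `NNC(=O)COc1ccncc1-c1ccc2ccccc2c1` with "not determined" (no result reported) in this assay, so no result was reported for it.

Among the two numbers shown, compound 3 has the higher one; its nearest neighbour is compound 1, and the step of a 6.9-fold higher number from compound 1 to compound 3 (0.84 log units; beyond the scatter) separates them. Compound 4 `COC(=O)/C=C/c1ccncc1-c1ccc2ccccc2c1` differs from compound 3 by hydrogen in place of methyl on a saturated chain carbon bound to an oxygen next to a carbonyl group, that is, ethoxycarbonyl to methoxycarbonyl. Within the data shown here, no measured step bears directly on this change: the step from compound 1 to compound 3 swaps out the whole side chain, not just one carbon of the ester. For so small a change, the expected step of a 1.1-fold lower number from compound 3 to compound 4 (0.03 log units; within the scatter) is none beyond the scatter. Compound 4 is therefore estimated at 50 nM, with a range from 20 nM to 130 nM.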

Compound 4, half-maximal inhibitory concentration: 40.6 nM
Beside the measured number, compound 4's estimate is 1.2-fold (0.09 log units) above it; low and high end bracket the measured number.
By their numbers in this assay, from the lowest: compound 1; then compounds 4 and 3 (each within the scatter of the next).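

In this assay, shortening ethoxycarbonyl to methoxycarbonyl gives a 1.3-fold lower number from compound 3 to compound 4 (0.12 log units; within the scatter) and so shows no change that can be told from scatter at this end of the ester. The side chain as a whole still matters: 2-(methoxycarbonyl)ethenyl in place of 2-(aminocarbamoyl)ethyl gives a 5.3-fold higher number from compound 1 to compound 4 (0.72 log units; beyond the scatter) and so leaves the gap to compound 1 beyond the scatter with this ester too. No measurement shown explains either result. As far as these compounds go, compound 1 differs from both esters in its link and its end group together, so their separate shares stay open. A carboxylic acid on the ethenyl chain, or a methyl ester on a saturated chain, would begin to separate them.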